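Chlorine position change from compound 2 to compound 3

A few compounds are considered here, and "the series" means these few. Any claim that something is new, unique, unknown or untested is made for them only; others in the source may bear on it.

Of the compounds shown here, two have been measured in an assay for inhibition of alkaline phosphatase, tissue-nonspecific isozyme (Homo sapiens), read by spectrophotometry, with stated times of 10 min and 20 min; on this read-out lower numbers stand for stronger inhibition and higher numbers for weaker inhibition. Compound 1 `COc1ccc(/C=C2\NS(=O)(=O)c3ccccc3C2=O)cc1` gives 4040 nM in this assay. Compound 2 `O=C1/C(=C/c2cccc(Cl)c2)NS(=O)(=O)c2ccccc21` reaches only the limit of this assay, > 200000 nM, and so has no number of its own. Where the measured values sit is shown by the limit of > 200000 nM in this assay, at which 1 of the 2 values shown sits. Among the measured compounds shown here, no step between measured compounds is available, since compound 1 and compound 2 differ in more than one place.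

Compound 3 `O=C1/C(=C/c2ccc(Cl)cc2)NS(=O)(=O)c2ccccc21` has not been measured. It differs from compound 2 by 4-chlorophenyl in place of 3-chlorophenyl on a double-bonded chain carbon bound to a double-bonded ring carbon. With compound 2 at a limit, the step is expected to run toward stronger inhibition, an at least 6.6-fold lower number from compound 2 to compound 3 (0.82 log units; beyond the scatter), though its size is uncertain. Compound 3 is estimated at 30000 nM, within 3000 nM to 200000 nM, and a limit rather than a number remains possible.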

Compound 3, half-maximal inhibitory concentration: 250 nM
The estimate for compound 3 lay 120-fold (2.08 log units) above the measured number; measured number outside the range, below it.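

Moving the chlorine, 4-chlorophenyl in place of 3-chlorophenyl on a double-bonded chain carbon bound to a double-bonded ring carbon, gives an at least 800-fold lower number from compound 2 to compound 3 (2.90 log units; beyond the scatter) in this assay, with the same atoms joined differently. This place therefore responds to where the chlorine sits on the phenyl ring, and not merely to its presence. Chloro in place of methoxy on an aromatic carbon gives a 16-fold lower number from compound 1 to compound 3 (1.21 log units; beyond the scatter), so the methoxy of compound 1 is not needed for inhibition in this series.

The true size of the first step stays open because compound 2 reaches only a limit of the assay and not a number: the limit of > 200000 nM in this assay, at which 1 of the 3 values shown sits.
Also open, as far as these compounds go, is how an amine or a carboxylic acid in place of the chloro of compound 3 would read.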